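From 1H-pyrazol-4-yl to phenyl on the shared core

The compounds below may be only part of what the source reports. "The series", "measured", "known", "first", "only" and "open" are said of these compounds alone.

Measured so far in a physicochemical assay for lipophilicity; on this read-out lower numbers stand for lower lipophilicity and higher numbers for higher lipophilicity:
- Compound 1 `Cc1noc(C)c1-c1cc(C(=O)NC[C@H]2CC[C@H](CNC(=O)OC(C)(C)C)CC2)c2ccccc2n1`: 5
- Compound 2 `CC(C)(C)OC(=O)NC[C@H]1CC[C@H](CNC(=O)c2cc(-c3cn[nH]c3)nc3ccccc23)CC1`: 3.5

Compound 2 stands lowest of the two, beyond the scatter from compound 1. Compound 3 `CC(C)(C)OC(=O)NC[C@H]1CC[C@H](CNC(=O)c2cc(-c3ccccc3)nc3ccccc23)CC1` has phenyl in place of 1H-pyrazol-4-yl on an aromatic carbon. Going by the values given here, one measured step bears on this change, the large a number 1.50 log units lower from compound 1 to compound 2 (beyond the scatter), where 1H-pyrazol-4-yl also entered on an aromatic carbon. Removing that group again should give a large step upward in this assay, of similar size. The expected step is a number 1.50 log units higher from compound 2 to compound 3 (beyond the scatter). For compound 3 the estimated value is 5, with an expected range from 4.4 to 5.6.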

Compound 3, distribution coefficient: 5.9
For compound 3 the middle estimate is 0.90 log units below the measured one; the whole stated range lies below it.
By their numbers in this assay, from the lowest: compound 2; then compound 1; then compound 3.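

In this assay, phenyl in place of 1H-pyrazol-4-yl gives a number 2.40 log units higher from compound 2 to compound 3 (beyond the scatter), so this position spans a wider range than the first two compounds showed. Phenyl in place of 3,5-dimethyl-1,2-oxazol-4-yl gives a number 0.90 log units higher from compound 1 to compound 3 (beyond the scatter), which puts the all-carbon ring at the top of the three. Nothing measured here explains these differences.

Still open, going by these compounds, is where a pyridine ring, an amine or a carboxylic acid on this same aromatic carbon would fall in this assay. On these data alone, whether these steps keep their size on a different core also remains open.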